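The source may report more compounds than this note shows. Statements on the series, on what has been measured and on what is new or still open speak of the compounds shown alone.

In an ADME assay (liver) for metabolic stability, with Liver microsome (Rattus norvegicus) as the target, using microsomes (on this read-out higher numbers stand for fast clearance and lower numbers for slow clearance), compound 1 `O=c1[nH]c2ccc(-c3nnc(NCc4ccccc4)o3)cc2o1` gives 30 mL.min-1.g-1, compound 2 `c1ccc(CNc2nnc(-c3c[nH]c4ncccc34)o2)cc1` gives 40 mL.min-1.g-1 and compound 3 `Fc1cccc(CNc2nnc(-c3c[nH]c4ncccc34)o2)c1` gives 71 mL.min-1.g-1. Compound 3 thus lies within the usual scatter of compound 2, and its number stands above that of compound 1 by more than the scatter. Compound 4 `c1ccc(CNc2nnc(-c3c[nH]c4ncccc34)o2)nc1` differs from compound 3 in one place, on a saturated chain carbon bound to a nitrogen on an aromatic ring, where pyridin-2-yl stands in place of 3-fluorophenyl: pyridin-2-yl in place of 3-fluorophenyl on a saturated chain carbon bound to a nitrogen on an aromatic ring. Going by the values given here, only one measured step bears on this change, a 1.8-fold higher number from compound 2 to compound 3 (0.25 log units; within the scatter), with fluoro in place of hydrogen on an aromatic carbon. Compound 4 carries no fluoro, so compound 2 at 40 mL.min-1.g-1 is the nearest guide. Among the compounds with values here, no measured compound shows what a ring nitrogen does here, which leaves the estimate uncertain. The expected change is a 2.2-fold lower number from compound 3 to compound 4 (0.35 log units; beyond the scatter), towards slower clearance. For compound 4 the estimated value is 32 mL.min-1.g-1, with an expected range from 14 mL.min-1.g-1 to 65 mL.min-1.g-1.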

Compound 4, intrinsic clearance in microsomes: 14 mL.min-1.g-1
Estimate against measurement, compound 4: 2.3-fold (0.36 log units) above; low and high end bracket the measured number.
By their numbers in this assay, from the lowest: compound 4; then compounds 1, 2 and 3 (each within the scatter of the next, the first and the last beyond it).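

In this assay, the group on the saturated chain carbon bound to a nitrogen on an aromatic ring now shows a change beyond the scatter, with a 5.1-fold lower number from compound 3 to compound 4 (0.71 log units; beyond the scatter). The comparison with the unsubstituted phenyl group is the cleaner one. It involves no fluoro group and isolates the exchange of phenyl for pyridin-2-yl: a 2.9-fold lower number from compound 2 to compound 4 (0.46 log units; beyond the scatter), towards slower clearance, whereas the fluoro step on that ring stayed within the scatter. Nothing available here explains this drop.

As far as these compounds go, it remains open whether the result depends on where the ring nitrogen sits, as pyridin-3-yl or pyridin-4-yl would show, or whether a saturated ring such as piperidine would behave alike. Also open, from the compounds shown here alone, is whether pyridin-2-yl would lower the number in the same way on the core of compound 1.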